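Shortening the alkyne chain into an alkene: compound 3

The compounds below may be only part of what the source reports. "The series", "measured", "known", "first", "only" and "open" are said of these compounds alone.

Measured compounds:
- compound 1 `CC(=O)Nc1nc(-c2cccc(NS(=O)(=O)c3ccc(C#CCO)cc3)c2)cs1`: 81.3%
- compound 2 `CCCCCCCCC#Cc1ccc(S(=O)(=O)Nc2cccc(-c3csc(NC(C)=O)n3)c2)cc1`: 39.6%

In a functional assay on A-375 cells (Homo sapiens) for antiproliferative activity, read by trypan blue exclusion, with a stated time of 48 h, tested at 1 uM (a lower number here means a stronger effect, a higher number a weaker effect of the compound at the concentration tested), compound 2 gives 39.6%, the lowest of the two numbers and therefore the stronger effect; its nearest neighbour is compound 1 with 81.3%. Among the compounds with values here, the only step measured so far, a number 41.7 percentage points lower from compound 1 to compound 2 (beyond the scatter), came with heptyl in place of hydroxy on a saturated chain carbon bound to a triple-bonded carbon, a large change toward a stronger effect.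

Compound 3 `CCCCCC/C=C\c1ccc(S(=O)(=O)Nc2cccc(-c3csc(NC(C)=O)n3)c2)cc1` is not yet measured. It differs from compound 2 by a group of 8 heavy atoms (8 carbon; no ring) in place of a group of 10 heavy atoms (10 carbon; no ring), on an aromatic carbon. The chain is kept but is two carbons shorter and carries a double bond where compound 2 carries a triple bond. The step from compound 1 to compound 2 suggests that a long carbon chain at this place matters most, so a mild loss of effect, if any, is expected; compound 3 is expected to give 48% (range 30% to 70%), a step of a number 8.4 percentage points higher from compound 2 to compound 3 (within the scatter).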

Compound 3, a percentage reported as activity, at one concentration (the size of the read-out at that concentration, not a potency): 48.8%
Compound 3: middle estimate off by 0.8 percentage points, on the low side; the measured number falls inside the stated range.
By their numbers in this assay, from the lowest: compounds 2 and 3 (each within the scatter of the next); then compound 1.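

In this assay the dec-1-yn-1-yl group of compound 2 can give way to a chain of 8 carbon atoms with a double bond and the effect holds (a number 9.2 percentage points higher from compound 2 to compound 3 (within the scatter)). So at this place on the aromatic ring, neither the triple bond nor the full length of the decynyl chain is required, and a long carbon chain need not be exactly this one. The chain of compound 3 also keeps a clear advantage over the small hydroxy-ending group of compound 1 (a number 32.5 percentage points lower from compound 1 to compound 3 (beyond the scatter)), and no measurement on hand explains why these chains behave as they do.

Compound 2 and compound 3 differ in chain length and bond type together, so the contribution of each stays unresolved. Also open, on these data alone, is how a fully saturated octyl chain, or a long chain ending in an amine or a carboxylic acid, would fare here.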